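This account rests on a few compounds, and the source may have more. Where it says the series, first, only, none or still open, it means among the compounds named here.

Measured compounds:
compound 1, `CC(C)(C)Cc1c(/C=C/c2ccc(Cl)cc2)sc(N)c1C(=O)c1ccc(Cl)cc1`, 1%
compound 2, `CC(C)(C)Cc1c(-c2ccsc2)sc(N)c1C(=O)c1ccc(Cl)cc1`, 2%

In an assay on CHO cells for displacement of a labelled ligand from adenosine receptor A1 (Homo sapiens), read by scintillation counting, tested at 10 uM (a lower number here means less inhibition, a higher number more inhibition at the concentration tested (going by the name of the read-out)), compound 1 gives 1%, and compound 2 gives 2%. Among the compounds with values here, compound 2 thus has the higher of the two numbers, but the one measured step, a number 1 percentage points higher from compound 1 to compound 2 (within the scatter), is within the scatter, so the two compounds cannot be told apart on these data. Both sit at the low end of this assay.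

Compound 3, `CC(C)(C)Cc1c(-c2ccco2)sc(N)c1C(=O)c1ccc(Cl)cc1`, has not yet been measured. It differs from compound 2 in one place: furan-2-yl in place of thiophen-3-yl on an aromatic carbon. Within the data shown here, the only step that bears on this change is the one from compound 1 to compound 2, where the replacement of 2-(4-chlorophenyl)ethenyl by thiophen-3-yl at the same aromatic carbon left this assay unchanged within the scatter. A swap of one five-membered aromatic ring with one hetero atom for another at that carbon is a smaller change than that, so no step beyond the scatter is expected in this assay.

Compound 3 is therefore estimated to give 3%, within -5% to 12%, the expected step being a number 1 percentage points higher from compound 2 to compound 3 (within the scatter).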

Compound 3, a percentage reported as inhibition, at one concentration (the size of the read-out at that concentration, not a potency): 1%
Compound 3: middle estimate off by 2 percentage points, on the high side; the measured number falls inside the stated range.
By their numbers in this assay, from the lowest: compounds 1, 3 and 2 (each within the scatter of the next).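

At the aromatic carbon next to the ring sulfur, the exchange of thiophen-3-yl for furan-2-yl, in which oxygen takes the place of sulfur in a five-membered aromatic ring with 1 hetero atom, gives in this assay a number 1 percentage points lower from compound 2 to compound 3 (within the scatter). Furan-2-yl in place of the larger 2-(4-chlorophenyl)ethenyl group gives no change at the digits printed from compound 1 to compound 3 (within the scatter), so all three groups now tried at this carbon, two of them five-membered aromatic rings with different hetero atoms, stay within the scatter of one another at the low end of this assay. No separate evidence bearing on this result is available.

The compounds shown leave open whether any group at this carbon can move the number in this assay beyond the scatter, as none of them carries an amine, a carboxylic acid or a longer alkyl chain there. They also leave open whether a change elsewhere, at the neopentyl group or the amino group, would separate thiophen-3-yl from furan-2-yl, as both of those groups stay the same throughout.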